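The source may report more compounds than this note shows. Statements on the series, on what has been measured and on what is new or still open speak of the compounds shown alone.

Compound 1, with the structure `CN1C(C(=O)O)=C(O)c2ccccc2S1(=O)=O`, and compound 2, with the structure `CN1C(C(=O)Nc2ccc(O)cn2)=C(O)c2ccccc2S1(=O)=O`, share one core and were both tested in a functional assay on the whole organism for inhibition, with Rattus norvegicus as the target, with a stated time of 4 h, at a dose of 33 mg/kg by the oral route; on this read-out higher numbers stand for more inhibition at the one dose given (going by the name of the read-out) and lower numbers for less inhibition. In this assay compound 1 gives 0%, while compound 2 gives 17%. For the measured compounds named here, the one step between them, a number 17 percentage points higher from compound 1 to compound 2 (beyond the scatter), follows the replacement of one oxygen atom on the carbonyl carbon by a hydroxypyridinyl amide group. On the two numbers available, compound 2 stands highest, with compound 1 the nearest at a value lower by a margin beyond the scatter.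

Compound 3, with the structure `CN1C(C(=O)Nc2ncccc2O)=C(O)c2ccccc2S1(=O)=O`, is built from the same atoms as compound 2 but joined differently: 3-hydroxypyridin-2-yl in place of 5-hydroxypyridin-2-yl on an amide-type nitrogen. Going by the values given here, no measured step shows what moving the hydroxyl to another position on the pyridine ring does; the only step known concerns the whole ring entering in place of an oxygen atom, and it was modest. The expectation for compound 3 is therefore a step of a number 2 percentage points lower from compound 2 to compound 3 (within the scatter), that is, no change beyond the scatter. Compound 3 is estimated at 15%, within a range from 0% to 35%.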

Compound 3, a percentage reported as inhibition, in the whole organism at one dose (the size of the read-out at that dose, not a potency): 41%
Estimate against measurement, compound 3: 26 percentage points below, and the stated range ends below it.
By their numbers in this assay, from the lowest: compound 1; then compound 2; then compound 3.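

The position of the hydroxyl on the pyridine ring matters on its own in this assay. With the same heavy atoms and the same hydrogen-bond donor and acceptor counts on both sides, 3-hydroxypyridin-2-yl in place of 5-hydroxypyridin-2-yl on the amide-type nitrogen gives a number 24 percentage points higher from compound 2 to compound 3 (beyond the scatter) and thus separates two groups that the earlier step could not tell apart. Set against the free acid, the (3-hydroxypyridin-2-yl)amino group in place of hydroxy on the carbonyl carbon gives a number 41 percentage points higher from compound 1 to compound 3 (beyond the scatter) and shows that this replacement can bring a large step, not only the modest one seen with the 5-hydroxypyridin-2-yl group. Nothing available explains why one placement of the hydroxyl gives the higher number.

The compounds shown leave open whether the hydroxyl itself is needed in this placement, which a methoxy group or an amino group in its stead, or a plain pyridin-2-yl group, would test. They also leave open what the ring nitrogen contributes, a question that a hydroxyphenyl group on the amide-type nitrogen would address.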